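The source may hold more compounds than are shown below. What is called first, only, known or untested is meant among the compounds shown, and "the series" means these compounds.

Working notes on the series. The shared core is seen in compound 2, `Nc1ncnc(Oc2ccc(NC(=O)C3(C(=O)Nc4ccc(F)cc4)CC3)cc2F)c1/C=N/OCCCO`, and in compound 1, `N/N=C/c1c(N)ncnc1Oc1ccc(NC(=O)C2(C(=O)Nc3ccc(F)cc3)CC2)cc1F`. Among the compounds with values here, in a physicochemical assay for lipophilicity, using the shake flask method (on this read-out lower numbers stand for lower lipophilicity and higher numbers for higher lipophilicity), compound 2 gives 2.67, the higher of the two numbers so far; in this assay compound 1 gives 2.25. Within the data shown here, the single measured step, a number 0.42 log units higher from compound 1 to compound 2 (beyond the scatter), exchanged an amino group on a double-bonded nitrogen for 3-hydroxypropoxy.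

Compound 3, `CCOC(=O)CO/N=C/c1c(N)ncnc1Oc1ccc(NC(=O)C2(C(=O)Nc3ccc(F)cc3)CC2)cc1F`, is not yet measured in this assay. Relative to compound 2 the change is ethoxycarbonyl in place of 2-hydroxyethyl on a saturated chain carbon bound to an oxygen; cut one bond further out it reads 3-hydroxypropoxy to (ethoxycarbonyl)methoxy. The step from compound 1 to compound 2 concerns the same chain but different groups, so it bears on the present change only loosely, showing that this chain is a place where this assay responds by a modest amount. Here a hydrogen-bond donor leaves and an ester with two acceptors enters, and a rise is expected. Compound 3 is expected to give 3.4 in this assay, within 2.9 to 3.9. The expected step, a number 0.73 log units higher from compound 2 to compound 3 (beyond the scatter), would lie beyond the scatter and exceed the measured step.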

Compound 3, partition coefficient: 3.15
The estimate for compound 3 lay 0.25 log units above the measured number, within the range that was stated.
By their numbers in this assay, from the lowest: compound 1; then compound 2; then compound 3.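

In this assay the position on the saturated chain carbon bound to an oxygen now gives a second step beyond the scatter: ethoxycarbonyl in place of 2-hydroxyethyl, a change from 1 hydrogen-bond donor to 0 and from 1 hydrogen-bond acceptor to 2, gives a number 0.48 log units higher from compound 2 to compound 3 (beyond the scatter), so the read-out responds to a change within the chain and not only to replacing the amino group on the double-bonded nitrogen. Set against that amino group, (ethoxycarbonyl)methoxy gives a number 0.90 log units higher from compound 1 to compound 3 (beyond the scatter), which places compound 3 at the top of the three, its steps to both others being beyond the scatter. No measurement shown here accounts for either step.

The two compounds in this step differ in several counted features at once, so the contributions of the lost hydroxyl and the added ester cannot be separated. A methyl ether ending the 3-hydroxypropoxy chain, or a carboxylic acid or amine on the same chain, would show how far the read-out follows each feature, and whether any group here brings it below the level of compound 1.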